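This account rests on a few compounds, and the source may have more. Where it says the series, first, only, none or still open, it means among the compounds named here.

Compound 1 `CCCCCCCCCCCCCCCCNc1nc(=O)c2ncn([C@@H]3O[C@H](CO)[C@@H](O)[C@H]3O)c2c(=O)[nH]1`: > 500 ug/mL, a limit of the assay
Compound 2 `CCCCCCCCCCCCNc1nc(=O)c2c(ncn2Cc2ccc(OC)cc2)c(=O)[nH]1`: > 500 ug/mL, a limit of the assay

Both readings come from an assay on isolated protein for inhibition of ATP-dependent RNA helicase SUPV3L1, mitochondrial (Homo sapiens); a lower number here means a stronger inhibitor, a higher number a weaker inhibitor. Compound 1 stands at the limit of this assay, so nothing can be said about where within the weak range it falls. The same holds for compound 2, and this agreement is summed up in the limit of > 500 ug/mL in this assay, at which 2 of the 2 values shown sit. Going by the values given here, the two compounds share the core but differ in their chains and in the group on the ring nitrogen, so no single step connects them, and their two values show only that neither reaches a measurable number.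

Compound 3 `CCCCCCCCCCCCCCCCCCNc1nc(=O)c2ncn([C@@H]3O[C@H](CO)[C@@H](O)[C@H]3O)c2c(=O)[nH]1` is related to compound 1 by one change: ethyl in place of hydrogen on a saturated chain carbon, ten or more bonds along the chain from a nitrogen on an aromatic ring. Among the compounds with values here, the change sits far out along a saturated chain, away from the core, and the only comparable compound, compound 2, with its shorter chain, also sits at the limit.

The step from compound 1 to compound 3 in this assay is expected to be no larger than the usual scatter, as a step that the limit leaves unreadable from compound 1 to compound 3. Compound 3 is therefore estimated at 700 ug/mL, with a likely range from 300 ug/mL to 3000 ug/mL, most probably again reported only as a limit.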

Compound 3, half-maximal inhibitory concentration: > 500 ug/mL
Compound 3: no number, only a limit (the forecaster's own chance of this, stated with the estimate: 85%); the middle value lies beyond the limit too.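

The step from compound 1 to compound 3 cannot be read, because each of the two compounds gives only a limit and not a number, and compound 2 is no different: the limit of > 500 ug/mL in this assay, at which 3 of the 3 values shown sit.

The compounds shown leave open whether any compound on this shared core reaches a measurable value in this assay and whether chain length matters at all.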